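The source may report more compounds than this note shows. Statements on the series, on what has been measured and on what is new or still open speak of the compounds shown alone.

Measured in an in vitro ADME assay on microsomes from liver (Rattus norvegicus) for metabolic stability; a lower number here means slower removal, a higher number faster removal of the compound:
- Compound 1 `O=C(NC1CCS(=O)(=O)CC1)N1CCC(c2nc(-c3ccc4ccccc4n3)no2)CC1`: 8 mL.min-1.g-1
- Compound 2 `Cn1c(-c2noc(N3CCN(C(=O)NC4CCCCC4)CC3)n2)nc2ccccc21`: 119 mL.min-1.g-1

Compound 1 has the lower of these two numbers, and its gap to compound 2 lies beyond the usual scatter of repeated measurements. On this scale, compound 1 is therefore removed more slowly than compound 2.

Compound 3 `O=C(NC1CCCCC1)N1CCC(c2nc(-c3ccc4ccccc4n3)no2)CC1` keeps the core of compound 1 and changes one group, with cyclohexyl in place of 1,1-dioxothian-4-yl on an amide-type nitrogen.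

Among the compounds with values here, no measured pair shows this change on its own, so the data give no direct size for the step in this assay. Within the data shown here, the only hint comes from compound 2, which has a different core but also carries cyclohexyl on an amide-type nitrogen, and compound 2 gives 119 mL.min-1.g-1. On that single comparison, a large rise beyond the scatter is expected. The expected change is an 8.8-fold higher number from compound 1 to compound 3 (0.94 log units; beyond the scatter), and this estimate is uncertain. Compound 3 is estimated at 70 mL.min-1.g-1, with an expected range of 25 mL.min-1.g-1 to 190 mL.min-1.g-1.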

Compound 3, intrinsic clearance in microsomes: > 300 mL.min-1.g-1
Compound 3 was reported as a limit; the forecaster's own chance of this, stated with the estimate: 5%; middle value at least 4.2-fold (0.63 log units) away from the limit.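

In this assay, placing cyclohexyl in place of 1,1-dioxothian-4-yl on an amide-type nitrogen, with the rest of the molecule unchanged, gives an at least 37-fold higher number from compound 1 to compound 3 (1.57 log units; beyond the scatter). As far as these compounds go, compound 3 gives > 300 mL.min-1.g-1, and this is a limit of the assay rather than a number, so the step is a minimum and its full size stays unknown: the limit of > 300 mL.min-1.g-1 in this assay, at which 1 of the 3 values shown sits. Compound 2 differs from compound 1 in its core as well and could only hint at this, whereas this pair ties a change beyond the scatter to this one position, so the group on this nitrogen alone can decide whether a compound sits low on this scale or at its limit.

The pair cannot tell which part of 1,1-dioxothian-4-yl matters, the ring sulfur with its two oxygens or simply the presence of hetero atoms, and a group such as tetrahydropyran-4-yl or an amine such as piperidin-4-yl would help separate these. It also leaves open whether the same change would have a similar size on a different core, such as that of compound 2.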